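A few compounds are considered here, and "the series" means these few. Any claim that something is new, unique, unknown or untested is made for them only; others in the source may bear on it.

The three measured compounds share one core. Compound 1 is `Cc1ccc2[nH]c(C(=O)N[C@H]3CCN(S(=O)(=O)C4CC4)C[C@@H]3C(=O)NCCN(C)C)cc2c1`, compound 2 is `Cc1ccc2[nH]c(C(=O)N[C@H]3CCN(S(=O)(=O)N4CCCCC4)C[C@@H]3C(=O)NCCN(C)C)cc2c1` and compound 3 is `Cc1ccc2[nH]c(C(=O)N[C@H]3CN(S(=O)(=O)c4ccccc4)C[C@@H]3C(=O)NC[C@H]3CCCN3)cc2c1`. In an ADME assay on cells (Hepatocyte, Rattus norvegicus) for metabolic stability (a higher number here means faster removal of the compound, a lower number slower removal), compound 1 gives 7 uL/min, compound 2 gives 25 uL/min, and compound 3 gives 10 uL/min. Compound 3 stands second highest of the three numbers: its value and that of compound 1 lie within the scatter of each other, while compound 2 sits above it, beyond the scatter. Among the measured compounds shown here, the only one-place step in hand, a 3.6-fold higher number from compound 1 to compound 2 (0.55 log units; beyond the scatter), concerns a change on a sulfonyl sulfur and is modest.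

Compound 4 is `Cc1ccc2[nH]c(C(=O)N[C@H]3CN(S(=O)(=O)c4ccccc4)C[C@@H]3C(=O)N[C@H]3CCCNC3)cc2c1`. It differs from compound 3 on an amide-type nitrogen: piperidin-3-yl in place of (pyrrolidin-2-yl)methyl on an amide-type nitrogen. The two have the same atoms, joined differently. For the measured compounds named here, no measured step touches this position; the single step known sits on the sulfonyl sulfur and gives no guidance for a change on the amide-type nitrogen. With nothing to point either way, no step beyond the scatter is expected in this assay. The estimated step of no change at the digits printed from compound 3 to compound 4 (within the scatter) is expected to fall within the scatter. For compound 4 the estimate is 10 uL/min, with a range from 5 uL/min to 20 uL/min, and the measured number will decide.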

Compound 4, intrinsic clearance in a liver preparation (reported as CLH), per the amount of preparation that the assay uses: 7 uL/min
Compound 4: middle estimate off by 1.4-fold (0.15 log units), on the high side; the range from low to high includes it.
By their numbers in this assay, from the lowest: compounds 1, 4 and 3 (each within the scatter of the next); then compound 2.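

Among the compounds shown here, replacing (pyrrolidin-2-yl)methyl with piperidin-3-yl on the amide-type nitrogen gives a 1.4-fold lower number from compound 3 to compound 4 (0.15 log units; within the scatter) in this assay and provides the first reading at this position. The five-membered non-aromatic ring can therefore give way to a six-membered one, with the same atoms joined differently, without moving the number beyond the scatter in this pair, whereas the earlier step on the sulfonyl sulfur, a 3.6-fold higher number from compound 1 to compound 2 (0.55 log units; beyond the scatter), lay beyond it. Nothing available explains why compound 3 and compound 4 read alike in this assay.

This single pair shows only that one rearrangement on the amide-type nitrogen stays within the scatter with the phenylsulfonyl group in place, and it does not show whether the same change would behave alike with the cyclopropylsulfonyl or piperidin-1-ylsulfonyl groups of compound 1 and compound 2. Also open, on these data alone, are the opposite configuration of the piperidin-3-yl stereocentre and other groups on the amide-type nitrogen, such as a morpholine ring, a carboxylic acid or a longer chain ending in a primary amine.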